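The source may report more compounds than this note shows. Statements on the series, on what has been measured and on what is new or still open speak of the compounds shown alone.

Measured so far:
Compound 1 `COc1ccc(Oc2ccccc2-c2ccsc2S(=O)(=O)N2CCN(C(=O)Nc3ccc([N+](=O)[O-])cc3)CC2)cc1OC` gives > 50000 nM in a functional assay on RS4-11 cells (Homo sapiens) for inhibition, read by CCK-8 assay, with a stated time of 48 h (a lower number here means a stronger inhibitor, a higher number a weaker inhibitor), a limit of the assay.
Compound 2 `Nc1ccc(Oc2ccccc2-c2ccc(S(=O)(=O)NCCNC(=O)Nc3ccc(Cl)cc3)s2)cc1` gives 13600 nM.
Compound 3 `O=S(=O)(NCCNC(=S)Nc1cc(C(F)(F)F)cc(C(F)(F)F)c1)c1ccc(-c2ccccc2OCc2ccccc2)s1` gives > 50000 nM, again only a limit.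

Compound 3 thus sits at the weak end of what the assay can report, together with compound 1, because of the limit of > 50000 nM in this assay, at which 2 of the 3 values shown sit. Only compound 2 gives a real number. Compound 4 `O=S(=O)(NCCNC(=S)Nc1cc(C(F)(F)F)cc(C(F)(F)F)c1)c1ccc(-c2ccccc2O[C@H]2CC[C@@H](O)CC2)s1` differs from compound 3 in one place: 4-hydroxycyclohexyl in place of benzyl on an oxygen on an aromatic ring. For the measured compounds named here, no step between two measured compounds shows what such a change does here, so the expectation for compound 4 rests on compound 3 alone. It is expected that compound 4 stays weak, with a step of an at least 1.6-fold lower number from compound 3 to compound 4 (0.22 log units; that floor lies within the scatter) of uncertain direction and likely within the scatter. Compound 4 is estimated at 30000 nM, between 8000 nM and 100000 nM.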

Compound 4, half-maximal inhibitory concentration: 6300 nM
Compound 4: middle estimate off by 4.8-fold (0.68 log units), on the high side, and the stated range ends above it.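

In this assay, the group on this oxygen clearly matters: 4-hydroxycyclohexyl in place of benzyl brings an at least 7.9-fold lower number from compound 3 to compound 4 (0.89 log units; beyond the scatter). For the compounds shown here, this is the first step between two measured compounds here, and it lies beyond the scatter. Its full size stays unknown because compound 3 gives only a limit: the limit of > 50000 nM in this assay, at which 2 of the 4 values shown sit.

The compounds shown do not separate the effect of the hydroxyl from that of replacing the aromatic ring with a non-aromatic one, since both change together. A plain cyclohexyl, or a 4-aminocyclohexyl, on the same oxygen would help to tell these apart.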